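A Second Double Bond Enters a Macrolide Side Chain

The source may hold more compounds than are shown below. What is called first, only, known or untested is meant among the compounds shown, and "the series" means these compounds.

Three lactones have so far been tested in a functional assay on XF498 cells (Homo sapiens) for cytotoxicity; on this read-out higher numbers stand for an effect only at larger amounts of compound and lower numbers for an effect already at smaller amounts. Compound 1 `CCCCC/C=C\C[C@@H]1O[C@@H]1/C=C/[C@@H]1C/C=C\CCCC(=O)O1` gives 3.6 ug/mL. Compound 2 `CC/C=C\C/C=C\C[C@@H](O)[C@H](O)/C=C/[C@@H]1C/C=C\CCCC(=O)O1` gives 4.5 ug/mL in this assay. Compound 3 `CCCCC/C=C\C[C@H](O)C(/C=C/[C@@H]1C/C=C\CCCC(=O)O1)OC` gives 6.1 ug/mL. On paper compound 3 carries the largest of the three numbers, yet its gap to compound 2 and its gap to compound 1 both fall within the usual scatter of repeated measurements, so the three compounds cannot be separated on this read-out.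

Compound 4 `CC/C=C\C/C=C\C[C@H](O)C(/C=C/[C@@H]1C/C=C\CCCC(=O)O1)OC` has not yet been measured. It differs from compound 3 in one place: but-1-en-1-yl in place of butyl on a saturated chain carbon bound to a double-bonded chain carbon. Compound 2 already carries an octa-2,5-dien-1-yl chain of this kind and gives 4.5 ug/mL, a number that sits among the others rather than apart from them. For the measured compounds named here, nothing in the measured set suggests that adding the double bond moves the read-out; no pair of measured compounds differs in one place, so no step of this kind is known. The expected step of a 1.2-fold lower number from compound 3 to compound 4 (0.09 log units; within the scatter) is therefore estimated to lie within the scatter, in no particular direction. Compound 4 is expected to give 5 ug/mL in this assay, with a plausible range from 2.5 ug/mL to 10 ug/mL.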

Compound 4, concentration for half-maximal effect: 7.6 ug/mL
For compound 4 the middle estimate is 1.5-fold (0.18 log units) below the measured one; the range from low to high includes it.
By their numbers in this assay, from the lowest: compounds 1, 2, 3 and 4 (each within the scatter of the next, the first and the last beyond it).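

In this assay, the replacement of butyl by but-1-en-1-yl on a saturated chain carbon bound to a double-bonded chain carbon gives a 1.2-fold higher number from compound 3 to compound 4 (0.10 log units; within the scatter), and this step lies within the scatter. For the compounds shown here, it is the first direct reading of this change, since no two of the earlier compounds differed in one place, and it shows that at this position the added double bond does not separate the two compounds on this read-out. No measurement at hand bears on the reason for this result.

As far as these compounds go, the reading rests on a single pair, so it remains open whether the same change would also stay within the scatter on the core of compound 1, where the rest of the molecule differs. From the compounds shown here alone, it also remains open whether a group of another kind at this place, such as an amine, a carboxylic acid or a longer chain, would move the read-out beyond the scatter or leave it as undivided as these four compounds.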